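From 2-Bromophenyl to 2-Phenylethenyl on the Ether Chain

The source may report more compounds than this note shows. Statements on the series, on what has been measured and on what is new or still open speak of the compounds shown alone.

In a functional assay on PC-3 cells (Homo sapiens) for inhibition, read by MTT assay, with a stated time of 48 h, tested at 10 uM (on this read-out lower numbers stand for less inhibition of growth and higher numbers for more inhibition of growth at the one concentration tested), compound 1 `Cc1cc(=O)c2c(O)cc(OCc3ccccc3)c([C@H]3CCN(C)C[C@H]3O)c2o1` gives 41%, compound 2 `Cc1cc(=O)c2c(O)cc(OCc3ccc(Br)cc3)c([C@H]3CCN(C)C[C@H]3O)c2o1` gives 17% and compound 3 `Cc1cc(=O)c2c(O)cc(OCc3ccccc3Br)c([C@H]3CCN(C)C[C@H]3O)c2o1` gives 32%. The value of compound 3 therefore lies within the scatter of compound 1 and beyond the scatter above compound 2.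

Compound 4 `Cc1cc(=O)c2c(O)cc(OC/C=C/c3ccccc3)c([C@H]3CCN(C)C[C@H]3O)c2o1` carries 2-phenylethenyl in place of 2-bromophenyl on a saturated chain carbon bound to an oxygen on an aromatic ring. Read one bond further out, this is 2-bromobenzyl changing to 3-phenylprop-2-en-1-yl.

Among the measured compounds shown here, three measured steps bear on this change, all within the same aromatic group. Bromo in place of hydrogen gave a number 24 percentage points lower from compound 1 to compound 2 (beyond the scatter) and also a number 9 percentage points lower from compound 1 to compound 3 (within the scatter), while 2-bromophenyl in place of 4-bromophenyl gave a number 15 percentage points higher from compound 2 to compound 3 (beyond the scatter). Compound 4 has no bromo, and the closest guide is the step of a number 9 percentage points lower from compound 1 to compound 3 (within the scatter), which removes nothing measurable from the scatter. For the measured compounds named here, no measured compound carries 2-phenylethenyl, so the double bond remains untested and the range must stay wide.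

In this assay, no step beyond the scatter is expected, and the estimate is a number 2 percentage points higher from compound 3 to compound 4 (within the scatter). For compound 4 the expected value is 34%, with an estimated range from 15% to 52%.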

Compound 4, percent growth inhibition at one concentration: 18%
For compound 4 the middle estimate is 16 percentage points above the measured one; the measured number falls inside the stated range.
By their numbers in this assay, from the lowest: compounds 2 and 4 (each within the scatter of the next); then compounds 3 and 1 (each within the scatter of the next).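

In this assay, the position on the saturated chain carbon bound to an oxygen on an aromatic ring proves sensitive to a change that brings in no bromo: 2-phenylethenyl in place of 2-bromophenyl gives a number 14 percentage points lower from compound 3 to compound 4 (beyond the scatter), and 2-phenylethenyl in place of phenyl gives a number 23 percentage points lower from compound 1 to compound 4 (beyond the scatter). Among the earlier compounds, only 4-bromophenyl had stood clearly apart from the unsubstituted phenyl, but 2-phenylethenyl now stands with it, at a number 1 percentage points higher from compound 2 to compound 4 (within the scatter), so a bromo on the ring is not needed for a number this low. Nothing in the data shown accounts for these steps.

The compounds shown do not separate the double bond from the longer chain, so it remains open what a saturated 3-phenylpropyl group would give on the same oxygen, and whether the cis form of 3-phenylprop-2-en-1-yl would match compound 4. Also open, as far as these compounds go, is how a simple 2-aminoethyl group or a pyridin-3-ylmethyl group would read at this position, and whether these steps would hold at any other concentration.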